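Cyanoguanidine series: trifluoromethyl for methoxy on the sulfonyl aryl

This account rests on a few compounds, and the source may have more. Where it says the series, first, only, none or still open, it means among the compounds named here.

Of the compounds shown here, two have numbers so far. Compound 1 `N#C/N=C(\NCc1ccc(S(=O)(=O)c2ccccc2)cc1)Nc1cccnc1` gives 30 nM in a functional assay on A2780 cells (Homo sapiens) for antiproliferative activity, read by sulforhodamine B assay, with a stated time of 72 h; a lower number here means a stronger inhibitor, a higher number a weaker inhibitor. Compound 2 `COc1cccc(S(=O)(=O)c2ccc(CN/C(=N\C#N)Nc3ccncc3)cc2)c1` gives 3.4 nM in this assay and so stands as the lower of the two numbers, a gap that is beyond the usual scatter of repeated measurements. For the measured compounds named here, compounds 1 and 2 differ in more than one place, so no single step between them is recorded; only the two values themselves are available.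

Compound 3 `N#C/N=C(\NCc1ccc(S(=O)(=O)c2cccc(C(F)(F)F)c2)cc1)Nc1ccncc1` has not yet been measured. It differs from compound 2 by one change: trifluoromethyl in place of methoxy on an aromatic carbon. Going by the values given here, no measured pair in this set shows the same change, so no step size is on record for it. The expectation is a step that stays within the usual scatter or falls only slightly toward a higher number, since the change leaves the shared core and the sulfone untouched. On that basis compound 3 is estimated at 5 nM in this assay, with a range from 1.5 nM to 20 nM, which means an expected step of a 1.5-fold higher number from compound 2 to compound 3 (0.17 log units; within the scatter).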

Compound 3, half-maximal inhibitory concentration: 2.9 nM
Beside the measured number, compound 3's estimate is 1.7-fold (0.24 log units) above it; measured number inside the range.
By their numbers in this assay, from the lowest: compounds 3 and 2 (each within the scatter of the next); then compound 1.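

In this assay, for the compounds shown here, the step of a 1.2-fold lower number from compound 2 to compound 3 (0.07 log units; within the scatter) gives the first reading for this change, and it lies within the scatter, so the assay does not separate the two groups at this position. On this aromatic carbon, meta to a large group, the 3-methoxyphenyl and 3-(trifluoromethyl)phenyl versions therefore stand level, even though the hydrogen-bond acceptor counted on methoxy is absent from trifluoromethyl and the group entering has more heavy atoms than the group leaving. No supporting data on hand bear on why the two values stand level.

This single pair leaves open how far the tolerance at this carbon extends, since a primary amine, a carboxylic acid or a longer chain such as butoxy would each test it with a group unlike either methoxy or trifluoromethyl. Also open, as far as these compounds go, is whether the same exchange would stay within the scatter on another carbon of this ring or on a compound with a different core, as one step cannot establish a pattern for the series.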